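The source may report more compounds than this note shows. Statements on the series, on what has been measured and on what is new or still open speak of the compounds shown alone.

Working notes on the series. The shared core of compound 1 `Cc1c(Oc2ccc(/C=C3\SC(=O)NC3=O)cc2)ncnc1OC1CCN(C(=O)OCc2ccccc2)CC1` carries a benzyloxycarbonyl on the piperidine nitrogen and a methyl on the central core; compound 2 `CC(C)COC(=O)N1CCC(Oc2cc(Oc3ccc(/C=C4\SC(=O)NC4=O)cc3)ncn2)CC1` has the isobutoxycarbonyl and lacks that methyl. In a functional assay on CHO-K1 cells for agonist activity at Glucose-dependent insulinotropic receptor (Homo sapiens), read by cAMP accumulation and immunoassay, with a stated time of 1 h (on this read-out lower numbers stand for smaller maximal responses and higher numbers for larger maximal responses), compound 2 gives 51%, and compound 1 gives 43.3%; the two numbers lie within the usual scatter of each other, so no order between them is read. Among the compounds with values here, no step between measured compounds is recorded.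

Compound 3 `O=C1NC(=O)/C(=C/c2ccc(Oc3cc(OC4CCN(C(=O)OCc5ccccc5)CC4)ncn3)cc2)S1` differs from compound 2 by phenyl in place of isopropyl on a saturated chain carbon bound to an oxygen next to a carbonyl group. Within the data shown here, compound 1 already carries the benzyloxycarbonyl and sits near compound 2, which is the only guide here. The step from compound 2 is expected to be small, a number 5 percentage points lower from compound 2 to compound 3 (within the scatter), not beyond the scatter in either direction. Compound 3 is therefore estimated at 46% in this assay, with a range from 30% to 62%.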

Compound 3, largest response reached (Emax), in percent of the reference or control that the assay uses: 88.3%
Beside the measured number, compound 3's estimate is 42.3 percentage points below it; measured number above the stated range.
By their numbers in this assay, from the lowest: compounds 1 and 2 (each within the scatter of the next); then compound 3.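

In this assay, phenyl in place of isopropyl on a saturated chain carbon bound to an oxygen next to a carbonyl group gives a number 37.3 percentage points higher from compound 2 to compound 3 (beyond the scatter), so the group at this position matters when the methyl is absent. With the benzyloxycarbonyl held constant, hydrogen in place of methyl on an aromatic carbon gives a number 45 percentage points higher from compound 1 to compound 3 (beyond the scatter), so the methyl position matters as well, and among these three compounds the largest response occurs only where phenyl and that hydrogen occur together. No measurement here accounts for either step.

From the compounds shown here alone, it remains open whether the step follows the aromatic ring itself, which cyclohexyl, pyridyl or a longer chain such as phenethyl in place of phenyl would test. Going by these compounds, the effect of the methyl with an isobutoxycarbonyl also remains open.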